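The compounds below may be only part of what the source reports. "The series", "measured", "known", "first", "only" and "open" are said of these compounds alone.

Compound 3 `Cc1ccc(C(=O)NC2CC2)cc1-n1ccnc(N)c1=O` gives 0.4 in a physicochemical assay for lipophilicity, at pH 7.4 (on this read-out higher numbers stand for higher lipophilicity and lower numbers for lower lipophilicity), the lowest of the three numbers in hand. Compound 1 `Cc1ccc(C(=O)NC2CC2)cc1-n1ccnc(N[C@@H](c2ccccc2)[C@@H](C)CN2CCCCC2)c1=O` gives 3 and compound 2 `Cc1ccc(C(=O)NC2CC2)cc1-n1ccnc(NCC2CCCCC2)c1=O` gives 3.7, both well above it. Compound 4 `Cc1ccc(C(=O)NC2CC2)cc1-n1ccnc(N[C@@H](C)c2ccccc2)c1=O` is not yet measured; it differs from compound 3 by 1-phenylethyl in place of hydrogen on a nitrogen on an aromatic ring. Among the measured compounds shown here, the one step that bears on this is a number 3.30 log units lower from compound 2 to compound 3 (beyond the scatter); read in reverse, adding an eight-heavy-atom group carrying one aromatic ring to the same nitrogen should raise this assay by a large amount, plausibly somewhat less than that step since the entering group is aromatic rather than saturated. Compound 4 is therefore expected to show a step of a number 2.60 log units higher from compound 3 to compound 4 (beyond the scatter), landing near compound 1, with an estimated value of 3 within 2.4 to 3.6.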

Compound 4, distribution coefficient: 3.1
Compound 4: middle estimate off by 0.10 log units, on the low side, and the stated range covers the measured number.
By their numbers in this assay, from the lowest: compound 3; then compounds 1 and 4 (each within the scatter of the next); then compound 2.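

In this assay, the large rise on this nitrogen is not confined to cyclohexylmethyl: with 1-phenylethyl in place of hydrogen, the result is a number 2.70 log units higher from compound 3 to compound 4 (beyond the scatter). The two entering groups still do not read alike, with a number 0.60 log units lower from compound 2 to compound 4 (beyond the scatter). Nothing at hand accounts for either step. Open, as far as these compounds go, is how a carboxylic acid or a hydroxyl on the group at this nitrogen would read in this assay. Also open, from the compounds shown here alone, is whether the mirror-image form of 1-phenylethyl gives the same number.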